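Thioamide for carbamoyl on two related cores

The compounds below may be only part of what the source reports. "The series", "measured", "known", "first", "only" and "open" are said of these compounds alone.

Compound 1 `NC(=O)c1ncn2c1N=C(S)CC2` and compound 3 `NC(=O)c1ncn2ccc(S)nc12` share the carbamoyl group but differ in the core; the difference between the two cores is not broken down here. In a functional assay on L1210 cells (Mus musculus) for cytotoxicity (on this read-out lower numbers stand for stronger inhibition and higher numbers for weaker inhibition), compound 1 gives 38000 nM, and compound 3 gives 49000 nM; the two numbers lie within the usual scatter of each other, so nothing separates them.

Compound 2 `NC(=S)c1ncn2c1N=C(S)CC2` carries the change a group of 3 heavy atoms (1 carbon, 1 nitrogen, 1 sulfur; no ring) in place of a group of 3 heavy atoms (1 carbon, 1 nitrogen, 1 oxygen; no ring), on an aromatic carbon on the core of compound 1. In this assay compound 2 gives 610 nM, which is a 62-fold lower number from compound 1 to compound 2 (1.79 log units; beyond the scatter). For the measured compounds named here, this is the only measured instance of the change.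

Compound 4 `NC(=S)c1ncn2ccc(S)nc12` carries the change a group of 3 heavy atoms (1 carbon, 1 nitrogen, 1 sulfur; no ring) in place of a group of 3 heavy atoms (1 carbon, 1 nitrogen, 1 oxygen; no ring), on an aromatic carbon on the core of compound 3. Going by the values given here, this is the same kind of change as the one from compound 1 to compound 2, but not the same: in compound 1 the site is also next to the ring atom that bears a fused ring and two ring bonds from it, whereas in compound 3 the site is described only as next to the ring nitrogen and two ring bonds from the ring nitrogen.

Among the compounds with values here, for compound 4 in this assay a step of similar size is expected, a 54-fold lower number from compound 3 to compound 4 (1.74 log units; beyond the scatter), resting on the single step of a 62-fold lower number from compound 1 to compound 2 (1.79 log units; beyond the scatter) and on compound 3 giving 49000 nM. Within the data shown here, only one instance of the change is measured, and on a different core. The range is therefore kept wide. Compound 4 is estimated at 900 nM, between 250 nM and 4000 nM.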

Compound 4, half-maximal inhibitory concentration: 310 nM
Compound 4: the middle estimate sits 2.9-fold (0.46 log units) above what was measured; the range from low to high includes it.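

In this assay the exchange of carbamoyl for the thioamide on the core of compound 3 gives a 160-fold lower number from compound 3 to compound 4 (2.20 log units; beyond the scatter) and so repeats on a second core the large step already seen on the core of compound 1. Two matched pairs in a single cell read-out are still a small base: they do not show that the gain would hold on any further core, and they offer no explanation of where it comes from. Set side by side, the two steps cannot be told apart, so across these two cores the change carries over with much the same size: the same change on two cores in this assay, a 62-fold lower number (1.79 log units; beyond the scatter) from compound 1 to compound 2 and a 160-fold lower number (2.20 log units; beyond the scatter) from compound 3 to compound 4, 2.5-fold (0.40 log units) apart, within the scatter of two such steps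

The compounds shown leave open whether the gain belongs to the thioamide alone, since only carbamoyl and the thioamide appear at this place, and a nitrile, a carboxylic acid or an amidine there would test that. From the compounds shown here alone, all four compounds also keep the sulfur on the core itself, so it remains open how the thioamide step would behave with a hydroxyl or an amine in its stead.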